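Swapping the chloropyridine for a chlorothiazole on the amide

A few compounds are considered here, and "the series" means these few. Any claim that something is new, unique, unknown or untested is made for them only; others in the source may bear on it.

Measured in an ADME assay on BJ cells (Homo sapiens) for inhibition, with a stated time of 72 h; on this read-out higher numbers stand for an effect only at larger amounts of compound and lower numbers for an effect already at smaller amounts:
Compound 1 `O=C(Nc1cccc(-c2nc3ccccc3s2)c1)c1ccc(Cl)nc1Cl` gives > 25000 nM, which is a limit of the assay and not a number.
Compound 2 `O=C(Nc1cccc(-c2nc3ccccc3s2)c1)c1ccncc1Cl` gives > 25000 nM, again a limit of the assay.

So compound 2 stands only at a limit; the change a step that the two limits leave unreadable from compound 1 to compound 2 is unreadable, since both values sit at the limit (the limit of > 25000 nM in this assay, at which 2 of the 2 values shown sit). Compound 3 `O=C(Nc1cccc(-c2nc3ccccc3s2)c1)c1cnc(Cl)s1` differs by 2-chloro-1,3-thiazol-5-yl in place of 3-chloropyridin-4-yl on a carbonyl carbon. Within the data shown here, no measured step is readable, so no shift beyond the scatter is expected: the estimated step of a number no higher from compound 2 to compound 3 (the limit leaves the size open) is none. Compound 3 is expected at 25000 nM, between 8000 nM and 100000 nM, most likely again only a limit.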

Compound 3, half-maximal effective concentration: > 25000 nM
Compound 3: only a limit was reported (the forecaster's own chance of this, stated with the estimate: 85%); the middle value sits exactly at the limit.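

The steps from compound 1 and from compound 2 to compound 3 cannot be read, as all three values are limits of the assay and not numbers: the limit of > 25000 nM in this assay, at which 3 of the 3 values shown sit.

As far as these compounds go, whether any of these ring swaps changes the read-out in this assay stays open.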